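A few compounds are considered here, and "the series" means these few. Any claim that something is new, unique, unknown or untested is made for them only; others in the source may bear on it.

Compound 3 `C/C(=C\CC/C(C)=C/CC[C@@H]1[C@@]2(C)CCC(=O)C(C)(C)[C@H]2CC[C@@]1(C)O)CC/C=C(\C)C(=O)OCc1cn(-c2ccccc2Br)nn1` is one of three close analogues that share a core and differ only in the aryl group on the triazole. In an ADME assay on L132 cells (Homo sapiens) for cytotoxicity, read by MTT assay, with a stated time of 48 h (a lower number here means a stronger inhibitor, a higher number a weaker inhibitor), compound 3 gives only a limit, > 150000 nM. Compound 1 `C/C(=C\CC/C(C)=C/CC[C@@H]1[C@@]2(C)CCC(=O)C(C)(C)[C@H]2CC[C@@]1(C)O)CC/C=C(\C)C(=O)OCc1cn(-c2ccccc2C(F)(F)F)nn1` likewise gives a limit in this assay, > 150000 nM. Compound 2 `C/C(=C\CC/C(C)=C/CC[C@@H]1[C@@]2(C)CCC(=O)C(C)(C)[C@H]2CC[C@@]1(C)O)CC/C=C(\C)C(=O)OCc1cn(-c2ccccc2)nn1` also rests at a limit in this assay, > 150000 nM. The steps between them are accordingly unreadable: a step that the two limits leave unreadable from compound 1 to compound 2, a step that the two limits leave unreadable from compound 1 to compound 3 and a step that the two limits leave unreadable from compound 2 to compound 3, since every value sits at the limit of > 150000 nM in this assay, at which 3 of the 3 values shown sit. Compound 4 `C/C(=C\CC/C(C)=C/CC[C@@H]1[C@@]2(C)CCC(=O)C(C)(C)[C@H]2CC[C@@]1(C)O)CC/C=C(\C)C(=O)OCc1cn(-c2cccc(C)c2)nn1` has not yet been measured in this assay. It differs from compound 3 by 3-methylphenyl in place of 2-bromophenyl on an aromatic nitrogen. Going by the values given here, the only measured steps that bear on this change are the three unreadable ones, so neither a size nor a direction can be taken from them, and nothing among the measured values points to a number inside the range of the assay. Compound 4 is therefore expected to show no step beyond the scatter, a step that the limit leaves unreadable from compound 3 to compound 4, and most probably another limit. The estimate for compound 4 is 200000 nM, expected to lie between 100000 nM and 600000 nM.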

Compound 4, half-maximal inhibitory concentration: > 150000 nM
Compound 4: no number, only a limit; the forecaster's own chance of this, stated with the estimate: 85%; the middle value does not contradict the limit.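

Going by these compounds alone, no step from compound 1, compound 2 or compound 3 to compound 4 can be read in this assay, because all four compounds rest at the same limit: the limit of > 150000 nM in this assay, at which 4 of the 4 values shown sit. The compounds shown leave open whether any aryl group on the triazole would bring a value within the measurable range.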